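The source may hold more compounds than are shown below. What is called first, only, known or untested is meant among the compounds shown, and "the series" means these compounds.

Working notes on the series. In a physicochemical assay for solubility (on this read-out higher numbers stand for higher solubility and lower numbers for lower solubility), compound 1 `CN(C)CC(=O)N1CCC[C@H]1C(=O)N1CCC(NS(=O)(=O)c2cc(S(=O)(=O)c3ccccc3)ccc2C(F)(F)F)CC1` gives 100000 nM. Compound 2 `CN(C)c1ccc(C(=O)N2CCC[C@H]2C(=O)N2CCC(NS(=O)(=O)c3cc(S(=O)(=O)c4ccccc4)ccc3C(F)(F)F)CC2)cc1` gives 100000 nM, level with compound 1 at the digits shown, and compound 1 is its nearest neighbour on these numbers.

The next compound, compound 3 `O=C([C@@H]1CCCN1C(=O)c1ccncc1)N1CCC(NS(=O)(=O)c2cc(S(=O)(=O)c3ccccc3)ccc2C(F)(F)F)CC1`, is not yet measured. Its difference from compound 2 is pyridin-4-yl in place of 4-(dimethylamino)phenyl on a carbonyl carbon, which puts pyridin-4-yl in place of 4-(dimethylamino)phenyl on a carbonyl carbon, with the rest of the structure unchanged.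

Within the data shown here, one measured step bears on this change, as it falls on the same carbonyl carbon. That step shows no change at the digits printed from compound 1 to compound 2 (within the scatter), with 4-(dimethylamino)phenyl in place of (dimethylamino)methyl. Among the measured compounds shown here, it is a single step with a different pair of groups, and no measured compound yet carries pyridin-4-yl, so the evidence is thin. On that basis, no step beyond the scatter is expected in this assay, in either direction. The estimated step is no change at the digits printed from compound 2 to compound 3 (within the scatter). For compound 3 the estimated value is 100000 nM, with an expected range of 50000 nM to 130000 nM.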

Compound 3, solubility: 100000 nM
The estimate for compound 3 equals the measured number at the digits printed; the measured number falls inside the stated range.
By their numbers in this assay, from the lowest: compounds 1, 2 and 3 (each within the scatter of the next).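

In this assay, among these compounds, a third group on this carbonyl carbon, whose other neighbour is an amide-type nitrogen in a ring, gives no change at the digits printed from compound 2 to compound 3 (within the scatter) and, measured against the first compound of the series, no change at the digits printed from compound 1 to compound 3 (within the scatter). The earlier pair compared an open chain with a carbon-only aromatic ring, whereas this change removes 9 heavy atoms, puts in 6, and replaces the six-membered aromatic ring of carbon only with one holding 1 hetero atom, and this assay still shows no step beyond the scatter. No measurement in hand accounts for the matching numbers across these three groups.

As far as these compounds go, whether a carboxylic acid, a primary amine or a longer alkyl chain on the same carbonyl carbon would separate from these three compounds in this assay remains open. Also open, from the compounds shown here alone, is whether replacing the trifluoromethyl or phenylsulfonyl group on the shared core would give a step beyond the scatter, since all three compounds carry both groups unchanged.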